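Working notes on three measured analogues and one pending

The compounds below may be only part of what the source reports. "The series", "measured", "known", "first", "only" and "open" are said of these compounds alone.

compound 1 `O=C1CSC(c2ccc(F)cc2)N1CCN1CCCCC1`: 87%
compound 2 `COc1cccc(C2SCC(=O)N2CCN2CCCCC2)c1`: 84%
compound 3 `COc1ccccc1C1SCC(=O)N1CCN1CCCCC1`: 100%

All three were run in an ADME assay on Vero cells (Chlorocebus sabaeus) for cytotoxicity, read by neutral red uptake, tested at 98 ug/mL; on this read-out higher numbers stand for a weaker effect at the one concentration tested and lower numbers for a stronger effect. On these numbers compound 1 stands second highest of three; compound 2 lies within the scatter of it, while compound 3 sits beyond the scatter on the higher side, a weaker effect. Within the data shown here, no single-change step between measured compounds is available, so the numbers alone do not tie the aromatic substituent to the read-out. Compound 4 `O=C1CSC(c2ccc(O)cc2)N1CCN1CCCCC1` differs from compound 1 by hydroxy in place of fluoro on an aromatic carbon. Given the narrow span of the measured values, the expected step is a number 3 percentage points higher from compound 1 to compound 4 (within the scatter), none beyond the scatter. Compound 4 is accordingly estimated at 90%, with a range from 76% to 100%.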

Compound 4, a percentage reported as activity, at one concentration (the size of the read-out at that concentration, not a potency): 94%
The estimate for compound 4 lay 4 percentage points below the measured number; the measured number falls inside the stated range.
By their numbers in this assay, from the lowest: compounds 2, 1, 4 and 3 (each within the scatter of the next, the first and the last beyond it).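

In this assay, among these compounds, 4-fluorophenyl to 4-hydroxyphenyl gives the first single-change step: a number 7 percentage points higher from compound 1 to compound 4 (within the scatter). At this place, on an aromatic carbon para to a large group, the read-out therefore does not separate hydroxy from fluoro, although only hydroxy counts a hydrogen-bond donor and acceptor. No supporting data explain this step.

As far as these compounds go, whether an amine or a carboxylic acid at the same place would stand apart from fluoro in this assay remains open. One step also cannot show whether this holds on another position of the aromatic ring.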